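A few compounds are considered here, and "the series" means these few. Any claim that something is new, unique, unknown or untested is made for them only; others in the source may bear on it.

Measured compounds:

Compound 1 `COc1ccc2c(c1)/C(=C\c1c(Cl)n(Cc3cc(OC)c(OC)c(OC)c3)c3cc(C)c(OC)cc13)C(=O)N2` — 33100 nM
Compound 2 `O=C1Nc2ccc(Cl)cc2/C1=C\c1c(Cl)n(CCCc2ccccc2)c2ccccc12` — 2450 nM

Of the compounds shown here, two have been measured so far. In a functional assay on cells (Cancer cell lines, Homo sapiens) for cytotoxicity, with a stated time of 48 h (a higher number here means a weaker inhibitor of growth, a lower number a stronger inhibitor of growth), compound 2 gives 2450 nM, the lowest of the two numbers. Compound 1, built on the same shared core but carrying several methoxy groups, gives 33100 nM, a gap well beyond the usual scatter of such measurements. Compound 2 is therefore the stronger growth inhibitor of the pair.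

The next compound, compound 3 `O=C1Nc2ccccc2/C1=C\c1c(Cl)n(CCCc2ccccc2)c2ccccc12`, is compound 2 with a single change: hydrogen in place of chloro on an aromatic carbon. Going by the values given here, no step between two measured compounds of this kind is available, so the size of this change cannot be read from the numbers already in hand. Taking compound 2 as the only anchor, the expectation is a small step toward a higher number, of a size that may well sit within the scatter, a 1.6-fold higher number from compound 2 to compound 3 (0.21 log units; within the scatter). On that basis compound 3 is expected to give about 4000 nM in this assay, with a plausible range from 1500 nM to 12000 nM.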

Compound 3, concentration for 50% growth inhibition: 12000 nM
Compound 3: middle estimate off by 3.0-fold (0.48 log units), on the low side, and the stated range covers the measured number.
By their numbers in this assay, from the lowest: compound 2; then compound 3; then compound 1.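

Going by these compounds alone, replacing chloro with hydrogen on this aromatic carbon is the first change here that can be read on its own, and in this assay it gives a 4.9-fold higher number from compound 2 to compound 3 (0.69 log units; beyond the scatter) and this step lies beyond the scatter. The position, on a six-membered aromatic ring of carbon only that is part of a fused or bridged system of two rings, therefore matters for this read-out: with the rest of the molecule unchanged, the chloro compound is the stronger inhibitor of growth and the hydrogen compound the weaker. Nothing measured here explains why the number moves, so the step remains an observation without a known cause.

A single pair cannot show whether chloro is special at this position, or how a bromo, methyl or trifluoromethyl group in the same place would compare with chloro and hydrogen. Within the data shown here, it also leaves open whether the same change would give a step of similar size with a different chain on the shared core, since only this one pair carries it.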